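The source may report more compounds than this note shows. Statements on the series, on what has been measured and on what is new or still open speak of the compounds shown alone.

Compound 2 `Cc1ccc(S(=O)(=O)/N=C(/CCNC2=CC(=O)c3ccccc3C2=O)Nc2ccc(Cl)cc2)cc1` gives 29900 nM in a functional assay on A549 cells (Homo sapiens) for cytotoxicity, read by MTT assay, with a stated time of 48 h; a lower number here means a stronger inhibitor, a higher number a weaker inhibitor. On the numbers shown it stands alongside compound 1 `COc1ccc(N/C(CCNC2=CC(=O)c3ccccc3C2=O)=N\S(=O)(=O)c2ccc(C)cc2)cc1`, which gives 25500 nM in this assay, the two lying within the scatter of each other. The change to compound 3 `Cc1ccc(S(=O)(=O)/N=C(/CCNC2=CC(=O)c3ccccc3C2=O)Nc2ccc(F)cc2)cc1` is fluoro in place of chloro on an aromatic carbon, read one bond further out as 4-chlorophenyl to 4-fluorophenyl. For the measured compounds named here, the only measured step that touches this place, a 1.2-fold higher number from compound 1 to compound 2 (0.07 log units; within the scatter), stayed within the scatter, so for the present exchange no step beyond the scatter is expected either: a 1.1-fold lower number from compound 2 to compound 3 (0.03 log units; within the scatter). The estimate for compound 3 is therefore 28000 nM, with a range from 12000 nM to 65000 nM.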

Compound 3, half-maximal inhibitory concentration: 9330 nM
For compound 3 the middle estimate is 3.0-fold (0.48 log units) above the measured one; the whole stated range lies above it.
By their numbers in this assay, from the lowest: compound 3; then compounds 1 and 2 (each within the scatter of the next).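

This position is not silent in this assay: fluoro in place of chloro gives a 3.2-fold lower number from compound 2 to compound 3 (0.51 log units; beyond the scatter), and fluoro in place of methoxy gives a 2.7-fold lower number from compound 1 to compound 3 (0.44 log units; beyond the scatter), whereas the earlier exchange of methoxy for chloro showed no step beyond the scatter. Among these three groups on the aromatic carbon, only 4-fluorophenyl stands apart, with chloro and methoxy lying together. Nothing available gives a reason for this separation.

Open, going by these compounds, is whether a trifluoromethyl group, an amine or a carboxylic acid at this place would read with fluoro or with chloro and methoxy. Also open, on these data alone, is whether the fluoro step holds on other cell lines.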